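A few compounds are considered here, and "the series" means these few. Any claim that something is new, unique, unknown or untested is made for them only; others in the source may bear on it.

In a physicochemical assay for solubility, read by LC-MS, in phosphate buffer, measured as thermodynamic solubility, with a stated time of 24 h, at pH 7.4 (on this read-out higher numbers stand for higher solubility and lower numbers for lower solubility), compound 1 `Cn1cc(-c2cnc3[nH]cc(-c4ccccc4)c3c2)cn1` gives 20000 nM, compound 2 `COc1ccc(-c2c[nH]c3ncc(-c4cnn(C)c4)cc23)cc1` gives 5000 nM and compound 3 `Cn1cc(-c2cnc3[nH]cc(-c4cccc(F)c4)c3c2)cn1` gives 3000 nM. Compound 3 thus stands clearly under compound 1, while its value and that of compound 2 lie within the scatter of each other. Compound 4 `Cn1cc(-c2cnc3[nH]cc(-c4ccc(F)cc4)c3c2)cn1` has the same atoms joined differently: 4-fluorophenyl in place of 3-fluorophenyl on an aromatic carbon. It carries 4-fluorophenyl in place of 3-fluorophenyl on an aromatic carbon. Among the measured compounds shown here, two measured steps bear on this change. Fluoro in place of hydrogen on an aromatic carbon gave a 6.7-fold lower number from compound 1 to compound 3 (0.82 log units; beyond the scatter), and methoxy in place of hydrogen on an aromatic carbon gave a 4.0-fold lower number from compound 1 to compound 2 (0.60 log units; beyond the scatter). For the measured compounds named here, both are modest, but neither shows what moving the fluoro does, and no measured pair tests that directly. Since compound 4 keeps the fluoro of compound 3, which gives 3000 nM, no change beyond the scatter is expected. The estimated step is a 1.2-fold higher number from compound 3 to compound 4 (0.07 log units; within the scatter). For compound 4 the expected value is 3500 nM, with an estimated range of 1300 nM to 9000 nM.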

Compound 4, solubility: 9000 nM
For compound 4 the middle estimate is 2.6-fold (0.41 log units) below the measured one; low and high end bracket the measured number.
By their numbers in this assay, from the lowest: compounds 3, 2 and 4 (each within the scatter of the next, the first and the last beyond it); then compound 1.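

Moving the fluoro alone, with 4-fluorophenyl in place of 3-fluorophenyl on the same aromatic carbon, gives a 3.0-fold higher number from compound 3 to compound 4 (0.48 log units; beyond the scatter), so where the fluoro sits matters in its own right on this read-out, which no earlier pair could show. Fluoro in place of hydrogen now has two readings, a 6.7-fold lower number from compound 1 to compound 3 (0.82 log units; beyond the scatter) and a 2.2-fold lower number from compound 1 to compound 4 (0.35 log units; beyond the scatter), so its size depends on the place, while fluoro in place of methoxy gives a 1.8-fold higher number from compound 2 to compound 4 (0.26 log units; within the scatter). Nothing measured here explains why the two fluorophenyl compounds differ.

The compounds shown leave open whether another group on the phenyl ring, such as an amine or a carboxylic acid, would follow the fluoro or the methoxy. They also leave open how a second fluoro on that ring would read.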